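The source may report more compounds than this note shows. Statements on the series, on what has been measured and on what is new or still open speak of the compounds shown alone.

Working notes on the series. Compound 1 `Cc1ccc2oc(=O)c(/C=N/c3ccc(S(N)(=O)=O)cc3)c(Cl)c2c1` gives 360 nM in a functional assay on B16-F10 cells (Mus musculus) for cytotoxicity, read by CCK-8 assay, with a stated time of 48 h; a lower number here means a stronger inhibitor, a higher number a weaker inhibitor. Compound 2 `Cc1ccc2oc(=O)c(/C=N/c3ccc(S(=O)(=O)Nc4nc(C)cc(C)n4)cc3)c(Cl)c2c1` carries a 4,6-dimethylpyrimidin-2-yl on the sulfonamide nitrogen; in this assay compound 2 gives 300 nM, the lowest of the two numbers recorded, but the step of a 1.2-fold lower number from compound 1 to compound 2 (0.08 log units; within the scatter) is within the scatter, so compound 2 and compound 1 cannot be ordered. Compound 3 `Cc1ccc2oc(=O)c(/C=N/c3ccc(S(=O)(=O)Nc4cc(C)on4)cc3)c(Cl)c2c1` is not yet measured; it differs from compound 2 by 5-methyl-1,2-oxazol-3-yl in place of 4,6-dimethylpyrimidin-2-yl on a sulfonamide nitrogen. Within the data shown here, the only measured step that touches the sulfonamide nitrogen is a 1.2-fold lower number from compound 1 to compound 2 (0.08 log units; within the scatter), where adding a six-membered aromatic ring with 2 hetero atoms gave no change beyond the scatter. Exchanging that ring for a five-membered aromatic ring with 2 hetero atoms is therefore expected to leave the number near that of compound 2, with the step of a 1.1-fold higher number from compound 2 to compound 3 (0.03 log units; within the scatter) expected to stay within the scatter. For compound 3 the estimate in this assay is 320 nM, with a range from 150 nM to 700 nM.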

Compound 3, half-maximal inhibitory concentration: 250 nM
The estimate for compound 3 lay 1.3-fold (0.11 log units) above the measured number; low and high end bracket the measured number.
By their numbers in this assay, from the lowest: compounds 3, 2 and 1 (each within the scatter of the next).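

In this assay, the exchange of one ring for another on the sulfonamide nitrogen, a 1.2-fold lower number from compound 2 to compound 3 (0.08 log units; within the scatter), lies within the scatter, so going from a six-membered to a five-membered aromatic ring with 2 hetero atoms, with two fewer heavy atoms, gives no readable change. Set against the free sulfonamide, the step of a 1.4-fold lower number from compound 1 to compound 3 (0.16 log units; within the scatter) also lies within the scatter, so neither of the two rings on this nitrogen separates from hydrogen. No evidence is at hand that would explain these numbers.

Going by these compounds, whether a non-aromatic group on this nitrogen, such as a longer alkyl chain or a chain ending in a carboxylic acid or an amine, would move the number beyond the scatter remains open. On these data alone, the shared core is also unchanged throughout, so how much the number depends on it is open as well.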